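One Methyl on the Phenyl of Compound 3

The source may hold more compounds than are shown below. What is called first, only, known or untested is meant among the compounds shown, and "the series" means these compounds.

In a physicochemical assay for solubility, in phosphate buffer, at pH 7.4 (a lower number here means a less soluble compound, a higher number a more soluble compound), the measured compounds read as follows
Compound 1 `CCOC(=O)c1c(-c2ccc(C(F)(F)F)cc2)[nH]c2cccc(OC)c2c1=O` gives 22000 nM
Compound 2 `CCOC(=O)c1c(-c2ccc(OC)cc2)[nH]c2cccc(OC)c2c1=O` gives > 100000 nM as a limit
Compound 3 `CCOC(=O)c1c(-c2ccccc2)[nH]c2cccc(OC)c2c1=O` gives > 100000 nM as a limit

Compound 3 stands at > 100000 nM in this assay and that value is a limit, not a number. The top of these data is the limit of > 100000 nM in this assay, at which 2 of the 3 values shown sit, and only compound 1 carries a plain number.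

Compound 4 `CCOC(=O)c1c(-c2ccccc2C)[nH]c2cccc(OC)c2c1=O` differs from compound 3 by methyl in place of hydrogen on an aromatic carbon and the same difference reads phenyl to 2-methylphenyl.

Three measured steps change a group on an aromatic carbon, and none of them brings in methyl. Hydrogen in place of trifluoromethyl gave an at least 4.5-fold higher number from compound 1 to compound 3 (0.65 log units; beyond the scatter) and methoxy in place of trifluoromethyl gave an at least 4.5-fold higher number from compound 1 to compound 2 (0.65 log units; beyond the scatter), both beyond the scatter. Hydrogen in place of methoxy gave a step that the two limits leave unreadable from compound 2 to compound 3 and so adds nothing on size. Among the compounds with values here, these steps are only a loose guide, since compound 4 has no trifluoromethyl and the one plain number is that of compound 1 at 22000 nM. Compound 4 is therefore expected to stay close to the limit of compound 3.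

The expected step is an at least 1.1-fold lower number from compound 3 to compound 4 (0.04 log units; that floor lies within the scatter) and no move beyond the scatter is expected in either direction. For compound 4 the estimate is 90000 nM, with an expected range from 35000 nM to 120000 nM.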

Compound 4, solubility: > 100000 nM
Compound 4 gave a limit, no number; the forecaster's own chance of this, stated with the estimate: 55%; at least 1.1-fold (0.04 log units) between middle value and limit.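

In this assay compound 4 gives > 100000 nM, which is a limit and not a number. Compound 2 and compound 3 carry the same limit, so no step to compound 4 can be read from either: the limit of > 100000 nM in this assay, at which 3 of the 4 values shown sit.

The compounds shown leave open how far compound 2, compound 3 and compound 4 differ from one another in this assay.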